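Urea to amide within a shared series

This account rests on a few compounds, and the source may have more. Where it says the series, first, only, none or still open, it means among the compounds named here.

Compound 2 `COc1cc(Cl)cc(-c2nn(-c3cccc(NC(=O)Nc4ccc(Cl)c(C(F)(F)F)c4)c3)cc2-c2ccncc2)c1` is one of three measured analogues of a shared core, all tested in a functional assay on T47D cells (Homo sapiens) for inhibition, read by sulforhodamine B assay, with a stated time of 48 h, tested at 10 uM; on this read-out higher numbers stand for a weaker effect at the one concentration tested and lower numbers for a stronger effect. In this assay compound 2 gives 8.1%, the second highest of the three numbers. Compound 1 `O=C(Nc1cccc(-n2cc(-c3ccncc3)c(-c3cc(O)cc(Cl)c3)n2)c1)Nc1ccc(Cl)c(C(F)(F)F)c1` gives 25%, and the step of a number 16.9 percentage points lower from compound 1 to compound 2 (beyond the scatter) comes with methyl in place of hydrogen on an oxygen on an aromatic ring. Compound 3 `COc1cc(Cl)cc(-c2nn(-c3cccc(NC(=O)Nc4cc(C(F)(F)F)cc(C(F)(F)F)c4)c3)cc2-c2ccncc2)c1` gives 6.56%, which is within the scatter of compound 2.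

Compound 4 `COc1cc(Cl)cc(-c2nn(-c3cccc(NC(=O)c4cccc(C(F)(F)F)c4)c3)cc2-c2ccncc2)c1` is not yet measured. The change from compound 2 is 3-(trifluoromethyl)phenyl in place of (4-chloro-3-(trifluoromethyl)phenyl)amino on a carbonyl carbon. Going by the values given here, no measured step bears directly on this change: the pair of compound 2 and compound 3 only shows that two different aryl groups on the urea give values within the scatter of each other, and nothing shows what removing the (4-chloro-3-(trifluoromethyl)phenyl)amino group does. The expectation for compound 4 is therefore uncertain, leaning toward a weaker effect, with an estimated step of a number 26.9 percentage points higher from compound 2 to compound 4 (beyond the scatter). Compound 4 is estimated at 35%, within a range from 8% to 75%.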

Compound 4, a percentage reported as activity, at one concentration (the size of the read-out at that concentration, not a potency): 36.6%
Compound 4: middle estimate off by 1.6 percentage points, on the low side; the range from low to high includes it.
By their numbers in this assay, from the lowest: compounds 3 and 2 (each within the scatter of the next); then compound 1; then compound 4.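

In this assay, going by these compounds alone, the change on the carbonyl carbon gives a number 28.5 percentage points higher from compound 2 to compound 4 (beyond the scatter), the first step at this end of the molecule that lies beyond the scatter, whereas the two aryl ureas, compound 2 and compound 3, had stayed within the scatter of each other. The effect at this one concentration therefore depends on more than the choice of aryl group, since replacing the urea with an amide weakens it. The step removes the amino nitrogen, with its hydrogen-bond donor, and the chlorine together, so it cannot assign the change to either one. No measurement shown accounts for the step. The compounds shown leave open whether an amide with a 4-chloro-3-(trifluoromethyl)phenyl group would recover the effect, and how a sulfonamide or a methylene in place of the amino nitrogen would read.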